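The compounds below may be only part of what the source reports. "The series", "measured", "known", "first", "only" and "open" are said of these compounds alone.

Compound 3 `CCc1ccc2c(c1)c(=O)c(C(=O)Nc1ccc(Oc3ncnc4[nH]ccc34)c(F)c1)c(C)n2C` is the weakest-looking member of the three measured compounds in an assay on isolated protein for inhibition of tyrosine-protein kinase receptor UFO (Homo sapiens), read by FRET and Z'-LYTE, with a stated time of 1.5 h (on this read-out lower numbers stand for stronger inhibition and higher numbers for weaker inhibition), where compound 3 gives 157 nM. Its nearest neighbour is compound 2 `CCc1ccc2c(c1)c(=O)c(C(=O)Nc1ccc(Oc3ncnc4[nH]cc(-c5ccccc5)c34)cc1)c(C)n2C`, which in this assay gives 105 nM; these two numbers lie within the usual scatter of each other, so no order between them can be claimed. Compound 1 `CCc1ccc2c(c1)c(=O)c(C(=O)Nc1ccc(Oc3ncnc4[nH]cc(-c5ccccc5)c34)c(F)c1)c(C)n2C` stands far apart, giving 6 nM in this assay, and the two measured steps both lead away from it: an 18-fold higher number from compound 1 to compound 2 (1.24 log units; beyond the scatter) and a 26-fold higher number from compound 1 to compound 3 (1.42 log units; beyond the scatter).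

Compound 4 `CCc1ccc2c(c1)c(=O)c(C(=O)Nc1ccc(Oc3ccnc(Cl)c3)c(F)c1)c(C)n2C` has not yet been measured. It differs from compound 3 in one place: a group of 7 heavy atoms (5 carbon, 1 nitrogen, 1 chlorine; one six-membered aromatic ring with 1 hetero atom) in place of a group of 9 heavy atoms (6 carbon, 3 nitrogen; one five-membered aromatic ring with 1 hetero atom, one six-membered aromatic ring with 2 hetero atoms), on an oxygen on an aromatic ring. Going by the values given here, neither measured step touches this part of the molecule; the steps from compound 1 show only that changes near the ether-linked ring system move the number by large amounts. The replaced group carries a hydrogen-bond donor and two acceptors, and the entering 2-chloropyridin-4-yl carries none of the first and one of the second, so the expectation is a weaker result, with a step of a 4.5-fold higher number from compound 3 to compound 4 (0.65 log units; beyond the scatter) in this assay. The estimate for compound 4 in this assay is 700 nM, with a range from 150 nM to 4000 nM.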

Compound 4, half-maximal inhibitory concentration: > 10000 nM
Compound 4: no number, only a limit (the forecaster's own chance of this, stated with the estimate: 10%); middle value at least 14-fold (1.15 log units) away from the limit.
By their numbers in this assay, from the lowest: compound 1; then compounds 2 and 3 (each within the scatter of the next). At a limit, above all of these: compound 4.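

Compound 4 gives no number in this assay, only a limit: the limit of > 10000 nM in this assay, at which 1 of the 4 values shown sits.

The earlier steps shown here exchanged a fluoro or a phenyl and left the two-ring group on the oxygen in place, so they said nothing about that group itself. Here that group is replaced as a whole, and the result is an at least 63-fold higher number from compound 3 to compound 4 (1.80 log units; beyond the scatter), which shows that the 2-chloropyridin-4-yl is no working stand-in for it, even though the rest of the molecule stays the same.

Compound 3 still gives a measurable number without the phenyl of compound 1, so this position tolerates the removal of that one substituent far better than the exchange of the whole group on the oxygen.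

The compounds shown cannot separate the departure of the five-membered ring and its hydrogen-bond donor from the arrival of the chlorine, since all of these happen in a single step. They also leave open whether an amine in place of that chlorine would bring a measurable number back in this series.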